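The compounds below may be only part of what the source reports. "The series", "measured", "known", "first", "only" and "open" are said of these compounds alone.

Compound 2 `Cc1cc(C)n(CCOC2CC(=O)Nc3c2c(C)nn3-c2ncnc3nc[nH]c23)n1` shares its core with compound 1 `Cc1nn(-c2ncnc3nc[nH]c23)c2c1C(c1ccc(F)cc1Cl)CC(=O)N2` and compound 3 `Cc1nn(-c2ncnc3nc[nH]c23)c2c1C(C(=O)N(C)c1ccccc1)CC(=O)N2`, the three differing only at a saturated ring carbon. In a functional assay on HEK293 cells for agonist activity at G-protein coupled receptor 39 (Homo sapiens), read by scintillation proximity assay and inositol phosphate accumulation, with a stated time of 75 min, in the presence of a further agent that is not named here (a higher number here means that more compound is needed for the effect, a lower number that less compound is needed), compound 2 gives 16 nM, while compound 1 gives 9 nM and compound 3 gives 32 nM. Compound 2 stands second highest of the three numbers, with a 1.8-fold higher number from compound 1 to compound 2 (0.25 log units; within the scatter) and a 2.0-fold higher number from compound 2 to compound 3 (0.30 log units; within the scatter) both within the scatter. Compound 4 `COc1ccc(CCOC2CC(=O)Nc3c2c(C)nn3-c2ncnc3nc[nH]c23)cc1` differs from compound 2 by 4-methoxyphenyl in place of 3,5-dimethyl-1H-pyrazol-1-yl on a saturated chain carbon, two bonds along the chain from an oxygen on a saturated carbon. The measured steps that bear on this are the ring exchanges a 3.6-fold higher number from compound 1 to compound 3 (0.55 log units; beyond the scatter) and a 2.0-fold higher number from compound 2 to compound 3 (0.30 log units; within the scatter), of which only the first went beyond the scatter, and modestly. An exchange of one aromatic ring for another on this side chain is therefore expected to change little, a 1.3-fold higher number from compound 2 to compound 4 (0.10 log units; within the scatter). Compound 4 is estimated at 20 nM, within 8 nM to 50 nM.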

Compound 4, half-maximal effective concentration: 2 nM
Beside the measured number, compound 4's estimate is 10-fold (1.00 log units) above it; the whole stated range lies above it.
By their numbers in this assay, from the lowest: compound 4; then compounds 1, 2 and 3 (each within the scatter of the next, the first and the last beyond it).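

With the ether chain held fixed, exchanging only its terminal group gives an 8.0-fold lower number from compound 2 to compound 4 (0.90 log units; beyond the scatter) in this assay. The earlier steps shown here replaced the whole group on the saturated ring carbon, and the largest of them was a 3.6-fold higher number from compound 1 to compound 3 (0.55 log units; beyond the scatter); this step shows that the far end of the chain alone can move the number beyond the scatter. Nothing given here explains this step. On these data alone, whether it belongs to the methoxy or to the carbon-only ring stays open. So does what a plain phenyl, an amine or a longer chain would give at this place.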